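The source may hold more compounds than are shown below. What is called first, only, known or untested is meant among the compounds shown, and "the series" means these compounds.

Working notes on the series. Compound 3 `O=C1C(Nc2ccccc2C(F)(F)F)=C(Nc2ccccc2C(F)(F)F)C(=O)c2ccccc21` and compound 1 `O=C1C(Nc2ccccc2C(F)(F)F)=C(Nc2ccccc2C(F)(F)F)C(=O)c2c1cccc2[N+](=O)[O-]` share one core; in an ADME assay on L6 cells (Rattus norvegicus) for cytotoxicity, read by sulforhodamine B assay, with a stated time of 72 h (a higher number here means a weaker inhibitor, a lower number a stronger inhibitor), compound 3 gives 292000 nM, and compound 1 gives 88000 nM. For the measured compounds named here, the single change between them is nitro in place of hydrogen on an aromatic carbon, and it made a 3.3-fold lower number from compound 3 to compound 1 (0.52 log units; beyond the scatter).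

Compound 2 `Cc1ccc(NC2=C(Nc3ccc(C)cc3)C(=O)c3ccccc3C2=O)cc1` carries another core, and the difference between the two cores is not broken down here. In this assay compound 2 reports a limit, > 450000 nM, not a number; this is the limit of > 450000 nM in this assay, at which 1 of the 3 values shown sits.

Compound 4 `Cc1ccc(NC2=C(Nc3ccc(C)cc3)C(=O)c3c(cccc3[N+](=O)[O-])C2=O)cc1` is compound 2 with the same change, (nitro in place of hydrogen on an aromatic carbon), at a place described in the same words. From compound 2 to compound 4 a step of similar size is expected, an at least 2.2-fold lower number from compound 2 to compound 4 (0.35 log units; beyond the scatter), resting on a 3.3-fold lower number from compound 3 to compound 1 (0.52 log units; beyond the scatter), with the starting point uncertain since compound 2 is known only as a limit. For compound 4 in this assay the estimate is 200000 nM, expected between 80000 nM and 500000 nM.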

Compound 4, half-maximal inhibitory concentration: 172000 nM
Compound 4: the middle estimate sits 1.2-fold (0.07 log units) above what was measured; measured number inside the range.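

In this assay, nitro in place of hydrogen on an aromatic carbon again lowers the number on the second core, with an at least 2.6-fold lower number from compound 2 to compound 4 (0.41 log units; beyond the scatter). The direction of the change therefore carries across the two cores shown, but whether the size carries as well is not settled: the same change on two cores in this assay, a 3.3-fold lower number (0.52 log units; beyond the scatter) from compound 3 to compound 1 and an at least 2.6-fold lower number (0.41 log units; beyond the scatter) from compound 2 to compound 4; the limit leaves it open whether they differ. Compound 2 is known only as a limit, so the new step has no fixed starting point: the limit of > 450000 nM in this assay, at which 1 of the 4 values shown sits.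

The compounds shown leave open whether an amine or a carboxylic acid in place of that hydrogen would lower the number as nitro does. Also open, as far as these compounds go, is how nitro behaves on another aromatic carbon, or on a core beyond these two.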